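The source may hold more compounds than are shown below. What is called first, only, known or untested is meant among the compounds shown, and "the series" means these compounds.

Compound 1, with the structure `CNS(=O)(=O)c1cn(Cc2nc3cc(Cl)ccc3n2CCCS(C)(=O)=O)c2ccccc12`, is one of three compounds studied in an ADME assay on HEp-2 cells (Homo sapiens) for cytotoxicity, with a stated time of 4 days; on this read-out lower numbers stand for higher toxicity in this test and higher numbers for lower toxicity in this test. In this assay compound 1 gives only a limit of the assay, > 100000 nM, and not a number. The two companions give the same kind of result. Compound 2, `CS(=O)(=O)CCCn1c(Cn2cc(S(C)(=O)=O)c3cc(F)ccc32)nc2cc(Cl)ccc21`, reaches only the limit > 100000 nM in this assay. Compound 3, `CS(=O)(=O)CCCn1c(Cn2cc(S(C)(=O)=O)c3ccncc32)nc2cc(Cl)ccc21`, likewise reaches only the limit > 100000 nM in this assay. The whole picture is therefore summed up by the limit of > 100000 nM in this assay, at which 3 of the 3 values shown sit: compound 1 stands at the limit, with nothing measured in this assay that is a number and nothing that sets it apart from compound 2 or compound 3.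

Compound 4, `CS(=O)(=O)CCCn1c(Cn2cc(S(=O)(=O)C3CC3)c3ccccc32)nc2cc(Cl)ccc21`, has not been measured. It differs from compound 1 by cyclopropyl in place of methylamino on a sulfonyl sulfur, or methylsulfamoyl to cyclopropylsulfonyl. For the measured compounds named here, no step between measured compounds is known here, so there is nothing to show what this change does in this assay. Given that compound 1 sits at the limit, compound 4 is expected to move by a step that the limit leaves unreadable from compound 1 to compound 4, no step beyond the scatter. Compound 4 is estimated at 120000 nM, within the range 50000 nM to 400000 nM in this assay.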

Compound 4, half-maximal cytotoxic concentration: > 100000 nM
Compound 4 ended at the assay's limit (the forecaster's own chance of this, stated with the estimate: 80%); the middle value lies beyond the limit too.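

Compound 1 and compound 4 both give only a limit in this assay and not a number, and no step can be read between them. The compounds shown leave open what cyclopropyl in place of methylamino on a sulfonyl sulfur does in this assay.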